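The source may report more compounds than this note shows. Statements on the series, on what has been measured and on what is new or still open speak of the compounds shown alone.

Of the compounds shown here, three built on one shared core have been tested in a functional assay (aorta) with Rattus norvegicus as the target; a lower number here means a stronger inhibitor, a higher number a weaker inhibitor. Compound 1 `C/N=C(/S)C1(c2cccnc2)CCCC/C1=C\COc1ccccc1` gives 65 nM. Compound 2 `C/N=C(/S)[C@@]1(c2cccnc2)CCCC[C@@H]1CCOC(C)=O` gives 30 nM, the second highest of the three numbers, placed between compound 1 and compound 3 `C/N=C(/S)[C@@]1(c2cccnc2)CCCC[C@@H]1CCNS(=O)(=O)c1ccc(F)cc1`, which gives 7 nM, with both gaps beyond the scatter. Compound 4 `C/N=C(/S)[C@@]1(c2cccnc2)CCCC[C@@H]1CCNC(=O)C(C)C` has not yet been measured. It differs from compound 2 in one place: (isopropylcarbonyl)amino in place of acetoxy on a saturated chain carbon, two bonds along the chain from a saturated ring carbon. Among the compounds with values here, no pair of measured compounds shows this exact change, so any expectation rests on the three values alone, where compound 3 stands lowest. A modest drop beyond the scatter is expected, a 2.0-fold lower number from compound 2 to compound 4 (0.30 log units; within the scatter). Compound 4 is therefore estimated at 15 nM, with a range from 6 nM to 40 nM.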

Compound 4, concentration for 90% inhibition: 300 nM
Beside the measured number, compound 4's estimate is 20-fold (1.30 log units) below it; the measured number lies above the stated range.
By their numbers in this assay, from the lowest: compound 3; then compound 2; then compound 1; then compound 4.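

At this position, on a saturated chain carbon two bonds along the chain from a saturated ring carbon, this assay shows a 10-fold higher number from compound 2 to compound 4 (1.00 log units; beyond the scatter) when (isopropylcarbonyl)amino replaces acetoxy, so the inhibitor becomes clearly weaker and the group here strongly affects the read-out. The swap adds a hydrogen-bond donor and two heavy atoms together, and one step cannot separate these changes. No measurement shown explains the loss. Going by these compounds, whether it follows from the nitrogen link or the isopropyl end remains open; an acetylamino group on the same chain would help separate them.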